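A few compounds are considered here, and "the series" means these few. Any claim that something is new, unique, unknown or untested is made for them only; others in the source may bear on it.

Measured in a functional assay on RS4-11 cells (Homo sapiens) for inhibition, read by CCK-8 assay, with a stated time of 48 h; on this read-out higher numbers stand for weaker inhibition and lower numbers for stronger inhibition:
- compound 1 `COc1ccc(Oc2ccccc2-c2ccsc2S(=O)(=O)N2CCN(C(=S)Nc3cc(C(F)(F)F)cc(C(F)(F)F)c3)CC2)cc1OC`: > 50000 nM (a limit, not a number)
- compound 2 `O=S(=O)(c1sccc1-c1ccccc1Oc1ccc(O)c(O)c1)N1CCN(C(=S)Nc2ccc(Cl)cc2)CC1`: 7500 nM

Compound 1 has no number of its own and sits at the limit of > 50000 nM in this assay, at which 1 of the 2 values shown sits. Compound 3 `O=S(=O)(c1sccc1-c1ccccc1Oc1ccc(O)c(O)c1)N1CCN(C(=S)Nc2cc(C(F)(F)F)cc(C(F)(F)F)c2)CC1` keeps the rest of compound 1 and carries 3,4-dihydroxyphenyl in place of 3,4-dimethoxyphenyl on an oxygen on an aromatic ring. A large step towards stronger inhibition is expected in this assay, since compound 2, which also carries 3,4-dihydroxyphenyl, gives 7500 nM. The expected size of the change is an at least 10-fold lower number from compound 1 to compound 3 (1.00 log units; beyond the scatter). For compound 3 the estimated value is 5000 nM, with an expected range of 1200 nM to 25000 nM.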

Compound 3, half-maximal inhibitory concentration: 7300 nM
The estimate for compound 3 lay 1.5-fold (0.16 log units) below the measured number; measured number inside the range.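

In this assay, putting 3,4-dihydroxyphenyl in place of 3,4-dimethoxyphenyl on an oxygen on an aromatic ring gives an at least 6.8-fold lower number from compound 1 to compound 3 (0.83 log units; beyond the scatter). This single change, with the two trifluoromethyl groups of compound 1 kept, is enough to turn a compound without a measurable number into one with a number. The true step may be larger, because compound 1 has only a limit, not a number: the limit of > 50000 nM in this assay, at which 1 of the 3 values shown sits.

Still open, as far as these compounds go, is whether a phenyl ring carrying one hydroxyl and one methoxy, or an amine in place of a hydroxyl, would keep this gain.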